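Compound 3 to compound 4: ketone to alcohol

This account rests on a few compounds, and the source may have more. Where it says the series, first, only, none or still open, it means among the compounds named here.

compound 1 `CCn1c(C(=O)NCCN)ccc1C(CC)(CC)c1ccc(OCC(O)C(C)(C)C)c(C)c1`: 5.9 nM
compound 2 `C#CC(C)OC(=O)c1ccc(C(CC)(CC)c2ccc(OCC(O)C(C)(C)C)c(C)c2)n1CC`: > 50000 nM, a limit
compound 3 `CCn1c(C(=O)N(C)CC(=O)O)ccc1C(CC)(CC)c1ccc(OCC(=O)C(C)(C)C)c(C)c1`: 28600 nM

In a functional assay on MCF7 cells (Homo sapiens), read by MTT assay, with a stated time of 48 h (a lower number here means a stronger inhibitor, a higher number a weaker inhibitor), compound 3 gives the higher of the two exact numbers, 28600 nM, far from compound 1 at 5.9 nM. Compound 4 `CCn1c(C(=O)N(C)CC(=O)O)ccc1C(CC)(CC)c1ccc(OCC(O)C(C)(C)C)c(C)c1` differs from compound 3 by one change: 1-hydroxy-2,2-dimethylpropyl in place of (tert-butyl)carbonyl on a saturated chain carbon bound to an oxygen on an aromatic ring. For the measured compounds named here, no measured step covers this change. The only one, an at least 8400-fold higher number from compound 1 to compound 2 (3.92 log units; beyond the scatter), is large but concerns a different place, a carbonyl carbon. Compound 1 and compound 2 both carry 2-hydroxy-3,3-dimethylbutoxy, yet they lie far apart, so that group alone sets no clear direction. A moderate move to a lower number is expected, with wide uncertainty. The expected change is a 4.8-fold lower number from compound 3 to compound 4 (0.68 log units; beyond the scatter). Compound 4 is estimated at 6000 nM, with an expected range of 300 nM to 45000 nM.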

Compound 4, half-maximal inhibitory concentration: 25400 nM
The estimate for compound 4 lay 4.2-fold (0.63 log units) below the measured number, and the stated range covers the measured number.
By their numbers in this assay, from the lowest: compound 1; then compounds 4 and 3 (each within the scatter of the next). At a limit, above all of these: compound 2.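

In this assay, 1-hydroxy-2,2-dimethylpropyl in place of (tert-butyl)carbonyl on a saturated chain carbon bound to an oxygen on an aromatic ring gives a 1.1-fold lower number from compound 3 to compound 4 (0.05 log units; within the scatter), so the two groups are not told apart while (carboxymethyl)(methyl)amino sits on the carbonyl carbon. The change at that carbonyl carbon is far larger: (carboxymethyl)(methyl)amino in place of (2-aminoethyl)amino gives a 4300-fold higher number from compound 1 to compound 4 (3.63 log units; beyond the scatter). At the same carbon, (carboxymethyl)(methyl)amino in place of (1-methylprop-2-yn-1-yl)oxy gives an at least 1.9-fold lower number from compound 2 to compound 4 (0.29 log units; that floor lies within the scatter). That step rests on a limit and not on a number: the limit of > 50000 nM in this assay, at which 1 of the 4 values shown sits.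

Still open, on these data alone, is whether the ketone-to-alcohol change stays as small with (2-aminoethyl)amino on the carbonyl carbon. Also open, as far as these compounds go, is how a methyl ether or a longer chain in place of the hydroxyl would read.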